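The source may hold more compounds than are shown below. What is called first, only, known or untested is meant among the compounds shown, and "the series" means these compounds.

Working notes on the series built on the core of compound 1 (`COc1ccc(-n2c(S)nnc2-c2cc(OC)c(OC)c(OC)c2)cc1`), with compound 2 (`COc1ccc(-n2c(SC)nnc2-c2cc(OC)c(OC)c(OC)c2)cc1`) and compound 3 (`CCSc1nnc(-c2cc(OC)c(OC)c(OC)c2)n1-c1ccc(OC)cc1`) carrying alkyl groups on the sulfur. In a functional assay on HT-29 cells (Homo sapiens) for inhibition, read by MTT assay, with a stated time of 48 h (a higher number here means a weaker inhibitor, a lower number a stronger inhibitor), compound 1 gives > 60000 nM, which is a limit. In this assay compound 2 gives > 60000 nM, also a limit, so compound 2 has no number of its own. Compound 3 gives > 60000 nM, again a limit. Among the compounds with values here, the series so far stands at the limit of > 60000 nM in this assay, at which 3 of the 3 values shown sit.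

Compound 4 (`COc1ccc(-n2c(SCc3ccc(F)cc3)nnc2-c2cc(OC)c(OC)c(OC)c2)cc1`) follows from compound 2 by 4-fluorophenyl in place of hydrogen on a saturated chain carbon bound to a sulfur, which turns methylsulfanyl into (4-fluorobenzyl)sulfanyl. Within the data shown here, three measured steps bear on this: a step that the two limits leave unreadable from compound 1 to compound 2, a step that the two limits leave unreadable from compound 1 to compound 3 and a step that the two limits leave unreadable from compound 2 to compound 3. None of them has a readable size or direction, and the last, at the same place, involves no aromatic ring. A small move towards stronger inhibition is expected only tentatively, and another reading at the limit remains likely. The estimated move is an at least 1.5-fold lower number from compound 2 to compound 4 (0.17 log units; that floor lies within the scatter). For compound 4 the expected value is 40000 nM, with an estimated range of 6000 nM to 90000 nM.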

Compound 4, half-maximal inhibitory concentration: 50700 nM
For compound 4 the middle estimate is 1.3-fold (0.10 log units) below the measured one, and the stated range covers the measured number.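

Compound 4 is the only compound shown with a reading short of the limit in this assay, so 4-fluorobenzyl on the sulfur gives this position its first steps with a direction (an at least 1.1-fold lower number from compound 2 to compound 4 (0.07 log units; that floor lies within the scatter); an at least 1.1-fold lower number from compound 3 to compound 4 (0.07 log units; that floor lies within the scatter); an at least 1.1-fold lower number from compound 1 to compound 4 (0.07 log units; that floor lies within the scatter)). Within the data shown here, all three are floors that lie within the scatter, so they show only that a reading can be obtained with this group, not that the change brings a real gain in inhibition. The steps among the hydrogen, methyl and ethyl compounds still cannot be read, and those compounds stay at a limit: the limit of > 60000 nM in this assay, at which 3 of the 4 values shown sit.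

The compounds shown leave open what a plain benzyl or a longer chain ending in an amine would give on the sulfur, and so whether the step rests on the fluorine or on the aromatic ring. They also leave open whether any group at this position can bring the shared core to clearly lower numbers in this assay.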